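Swapping Chloro for Nitro on the Aryl Piperazine

The compounds below may be only part of what the source reports. "The series", "measured", "known", "first", "only" and "open" are said of these compounds alone.

Compound 1 `O=C(CN1CCN(c2ccccc2Cl)CC1)N1CCN(c2nnc(-c3ccccc3)c(-c3ccccc3)n2)CC1`: 263000 nM
Compound 2 `COc1ccc(N2CCN(CC(=O)N3CCN(c4nnc(-c5ccccc5)c(-c5ccccc5)n4)CC3)CC2)cc1`: > 910000 nM (a limit, not a number)
Compound 3 `O=C(CN1CCN(c2ccc(Cl)cc2)CC1)N1CCN(c2nnc(-c3ccccc3)c(-c3ccccc3)n2)CC1`: 56300 nM

In a functional assay on MCF7 cells (Homo sapiens) for cytotoxicity, read by MTT assay, with a stated time of 24 h (on this read-out lower numbers stand for stronger inhibition and higher numbers for weaker inhibition), compound 3 gives the lowest of the two real numbers; compound 1 sits a 4.7-fold lower number from compound 1 to compound 3 (0.67 log units; beyond the scatter) away. For compound 2 the assay reports only a limit.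

Compound 4 `O=C(CN1CCN(c2ccc([N+](=O)[O-])cc2)CC1)N1CCN(c2nnc(-c3ccccc3)c(-c3ccccc3)n2)CC1` changes compound 3 by nitro in place of chloro on an aromatic carbon. The step that bears most on this is an at least 16-fold lower number from compound 2 to compound 3 (1.20 log units; beyond the scatter), where a change of the same ring substituent moved the number a lot; a 4.7-fold lower number from compound 1 to compound 3 (0.67 log units; beyond the scatter) concerns position, not the group. Neither step covers nitro itself, so only a modest shift is expected for compound 4, a 1.4-fold higher number from compound 3 to compound 4 (0.15 log units; within the scatter). The estimate for compound 4 is 80000 nM, between 20000 nM and 320000 nM.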

Compound 4, half-maximal inhibitory concentration: > 886000 nM
Compound 4 was reported as a limit; the forecaster's own chance of this, stated with the estimate: 10%; middle value at least 11-fold (1.04 log units) away from the limit.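

In this assay, the chloro of compound 3 cannot be exchanged freely on this aromatic carbon: nitro gives an at least 15-fold higher number from compound 3 to compound 4 (1.19 log units; beyond the scatter). The value for compound 4 is a limit, not a number. The 4-nitrophenyl group also does worse than the 2-chlorophenyl group, with an at least 3.3-fold higher number from compound 1 to compound 4 (0.52 log units; beyond the scatter), so moving chloro to another place on the ring costs less here than replacing it with nitro.

Compound 2 and compound 4 are both limits, and the step between them cannot be read. Going by these compounds, it also remains open whether an amine or a carboxylic acid on this carbon would keep the number of compound 3.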